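The source may hold more compounds than are shown below. What is called first, only, known or untested is meant among the compounds shown, and "the series" means these compounds.

Of the compounds shown here, two with a shared core have been measured so far in an in vivo ADME assay on the whole organism (strain Sprague-Dawley) for pharmacokinetics, with Rattus norvegicus as the target; a higher number here means faster removal of the compound, a lower number slower removal. Compound 1 (`CC(C)C1(c2ccc(-c3ccc4ccccc4c3)[nH]c2=O)OC(=O)NC1=O`) gives 5.1 mL/min/kg, and compound 2 (`CC(C)C1(c2cc(Cl)c(-c3ccc4ccccc4c3)[nH]c2=O)OC(=O)NC1=O`) gives 1.2 mL/min/kg, the lower of the two numbers. The next compound, compound 3 (`Cc1cc(C2(C(C)C)OC(=O)NC2=O)c(=O)[nH]c1-c1ccc2ccccc2c1`), differs from compound 2 in a single group: methyl in place of chloro on an aromatic carbon. In other words, it has methyl in place of chloro on an aromatic carbon.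

For the measured compounds named here, only one measured step bears on this swap. Between the first two compounds lies a 4.3-fold lower number from compound 1 to compound 2 (0.63 log units; beyond the scatter), and it came with chloro in place of hydrogen on that same carbon. This step is modest in size but clearly larger than the scatter. Going by the values given here, no compound with methyl on this carbon has been measured, so the comparison is indirect. Methyl is neither the hydrogen of compound 1 nor the chloro of compound 2, so a result between those two compounds seems the most reasonable expectation. The expected change is a 2.1-fold higher number from compound 2 to compound 3 (0.32 log units; beyond the scatter), an upward move smaller than the measured one. For compound 3, the estimated clearance is 2.5 mL/min/kg, with an expected range from 1 mL/min/kg to 6 mL/min/kg.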

Compound 3, clearance: 1.4 mL/min/kg
The estimate for compound 3 lay 1.8-fold (0.25 log units) above the measured number; low and high end bracket the measured number.
By their numbers in this assay, from the lowest: compounds 2 and 3 (each within the scatter of the next); then compound 1.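

In this assay, the swap of chloro for methyl on this aromatic carbon comes out as a 1.2-fold higher number from compound 2 to compound 3 (0.07 log units; within the scatter), so this read-out does not tell the two groups apart. Measured against hydrogen on the same carbon, methyl gives a 3.6-fold lower number from compound 1 to compound 3 (0.56 log units; beyond the scatter), a step beyond the scatter in the same direction as a 4.3-fold lower number from compound 1 to compound 2 (0.63 log units; beyond the scatter), which shows that the lower number seen with chloro does not require chlorine: both groups of one heavy atom sit on the slower-removal side of compound 1. Nothing measured here explains why a group on this carbon goes with slower removal.

Still open, from the compounds shown here alone, is whether a larger group on this carbon, such as an ethyl or methoxy group, or a more different one, such as an amine, would keep the number as low as chloro and methyl do. Also open, going by these compounds, is whether the same picture would hold if the large groups elsewhere on this ring were changed, as all three compounds carry the same ones.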